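This account rests on a few compounds, and the source may have more. Where it says the series, first, only, none or still open, it means among the compounds named here.

Measured so far in a functional assay on HeLa cells (Homo sapiens) for antiproliferative activity, read by sulforhodamine B assay; a lower number here means a stronger inhibitor of growth, a higher number a weaker inhibitor of growth
- Compound 1 `CCC[C@@H]1O[C@H](COCc2ccc(F)cc2)[C@@H](OCc2ccc(F)cc2)[C@H](OCc2ccc(F)cc2)[C@H]1O`: 12300 nM
- Compound 2 `CCCC[C@@H]1O[C@H](COCc2ccccc2)[C@@H](OCc2ccccc2)[C@H](OCc2ccccc2)[C@H]1O`: > 50000 nM

Compound 2 stands at > 50000 nM in this assay, and this is a limit of the assay, not a number. Among the compounds with values here, compound 1 gives a true number, 12300 nM, but it differs from compound 2 in more than one place, so the two values offer no clean step.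

Compound 3 `OCCC[C@@H]1O[C@H](COCc2ccccc2)[C@@H](OCc2ccccc2)[C@H](OCc2ccccc2)[C@H]1O` departs from compound 2 by hydroxy in place of methyl on a saturated chain carbon, three bonds along the chain from a saturated ring carbon, so that butyl becomes 3-hydroxypropyl. Within the data shown here, with no measured step to guide it, only a modest gain in growth inhibition is expected, and compound 3 may also return only a limit. The expected step, an at least 1.4-fold lower number from compound 2 to compound 3 (0.15 log units; that floor lies within the scatter), is an estimate with wide uncertainty. For compound 3 a value of 35000 nM is expected, with an estimated range from 10000 nM to 90000 nM in this assay.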

Compound 3, concentration for 50% growth inhibition: > 50000 nM
Compound 3: no number, only a limit (the forecaster's own chance of this, stated with the estimate: 50%); at least 1.4-fold (0.15 log units) between middle value and limit.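

Compound 2 and compound 3 each return only a limit of the assay in this assay, so no step can be read between them: the limit of > 50000 nM in this assay, at which 2 of the 3 values shown sit.

The compounds shown leave open whether 3-hydroxypropyl in place of butyl changes growth inhibition at all, and in which direction.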